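Lengthening the Chain on the Ring Nitrogen

The compounds below may be only part of what the source reports. "The series", "measured", "known", "first", "only" and "open" are said of these compounds alone.

Measured so far:
compound 1, `COc1ccccc1CSc1nc2cc(NC(=O)C3CC3)ccc2n1C(C)C`, > 10000 nM
compound 2, `COc1ccc([N+](=O)[O-])cc1CSc1nc2cc(NC(=O)NC(C)(C)C)ccc2n1C1CC1`, 860 nM
compound 3, `CCn1c(SCc2cc([N+](=O)[O-])ccc2OC)nc2cc(NC(=O)NC(C)(C)C)ccc21`, 170 nM

Of the compounds shown here, three sharing one core have been tested in an assay on isolated protein for inhibition of Gonadotropin-releasing hormone receptor (Rattus norvegicus); a higher number here means a weaker inhibitor, a lower number a stronger inhibitor. Compound 1 reaches only a limit of this assay, (the limit of > 10000 nM in this assay, at which 1 of the 3 values shown sits), and gives no number. Among the measured compounds shown here, of the two numbers that exist, compound 3 stands lowest; its nearest neighbour is compound 2, and the step of a 5.1-fold lower number from compound 2 to compound 3 (0.70 log units; beyond the scatter) lies beyond the scatter, with ethyl in place of cyclopropyl on the aromatic nitrogen as the only change.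

Compound 4, `CCCn1c(SCc2cc([N+](=O)[O-])ccc2OC)nc2cc(NC(=O)NC(C)(C)C)ccc21`, differs from compound 3 by methyl in place of hydrogen on a saturated chain carbon, two bonds along the chain from an aromatic nitrogen; cut one bond further out, this reads as ethyl to propyl on the aromatic nitrogen. For the measured compounds named here, the one measured step that bears on this position is a 5.1-fold lower number from compound 2 to compound 3 (0.70 log units; beyond the scatter), which swapped a ring for a chain rather than lengthening a chain, so it speaks to the change only indirectly. A short extension of this kind is expected to move the number little, most likely within the scatter and with no firm direction.

For compound 4 the value in this assay is expected to be 150 nM, with a range of 50 nM to 450 nM, which means an expected step of a 1.1-fold lower number from compound 3 to compound 4 (0.05 log units; within the scatter).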

Compound 4, half-maximal inhibitory concentration: 120 nM
Compound 4: the middle estimate sits 1.3-fold (0.10 log units) above what was measured; low and high end bracket the measured number.
By their numbers in this assay, from the lowest: compounds 4 and 3 (each within the scatter of the next); then compound 2. At a limit, above all of these: compound 1.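

Lengthening ethyl to propyl on the aromatic nitrogen gives no readable change in this assay: the record is a 1.4-fold lower number from compound 3 to compound 4 (0.15 log units; within the scatter), so these two chains cannot be put in order. The propyl chain also stands clear of the ring, with a 7.2-fold lower number from compound 2 to compound 4 (0.86 log units; beyond the scatter) as the step for replacing cyclopropyl on that nitrogen. The advantage over cyclopropyl, seen earlier only with ethyl, therefore now holds for two chains, and neither of the two compounds with these chains goes against it, although that is as far as this pattern can be taken from three compounds. Nothing on hand bears on why the chains and the ring differ.

From the compounds shown here alone, how far this flat stretch extends remains open, since a butyl chain or a longer one on the aromatic nitrogen could either keep the number in the same range or shift it clearly. Going by these compounds, it is also open whether the position accepts a chain ending in an amine or a carboxylic acid, or whether a methyl group there, shorter than ethyl, would hold the number in the same range.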